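A few compounds are considered here, and "the series" means these few. Any claim that something is new, unique, unknown or untested is made for them only; others in the source may bear on it.

Measured so far:
Compound 1, `CC(=O)n1cc(/C=C(/C(=O)O)c2ccccc2)c2cc(OCc3ccccc3)ccc21`, gives > 100000 nM in a functional assay on M14 cells (Homo sapiens) for cytotoxicity, read by MTT assay, with a stated time of 72 h; on this read-out lower numbers stand for stronger inhibition and higher numbers for weaker inhibition.
Compound 2, `COc1cc(/C(=C\c2cn(C(C)=O)c3ccc(OCc4ccccc4)cc23)C(=O)O)cc(OC)c1OC`, gives 57100 nM.
Compound 3, `COc1ccccc1/C(=C\c1cn(C(C)=O)c2ccc(OCc3ccccc3)cc12)C(=O)O`, gives > 100000 nM.

The value of compound 3 is a limit of the assay, not a number. Compound 1 sits at the same limit, as the limit of > 100000 nM in this assay, at which 2 of the 3 values shown sit, records. Only compound 2 gives a readable number, and even that number lies far up the scale, so none of the three inhibits the cells strongly.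

Compound 4, `COc1ccc(OC)c(/C(=C\c2cn(C(C)=O)c3ccc(OCc4ccccc4)cc23)C(=O)O)c1`, differs from compound 3 by methoxy in place of hydrogen on an aromatic carbon. Among the measured steps, the one from compound 1 to compound 3 is the same kind of change, but a step that the two limits leave unreadable from compound 1 to compound 3, so it gives no guidance on size. The other two steps, an at least 1.7-fold higher number from compound 2 to compound 3 (0.24 log units; that floor lies within the scatter) and an at least 1.7-fold lower number from compound 1 to compound 2 (0.24 log units; that floor lies within the scatter), both involve the trimethoxyphenyl of compound 2 rather than the change from 2-methoxyphenyl to 2,5-dimethoxyphenyl, and each is only a floor within the scatter. With compound 3 at the limit, the expected step in this assay is an at least 1.2-fold lower number from compound 3 to compound 4 (0.09 log units; that floor lies within the scatter), most likely within the scatter, and a further limit is about as likely as a number. Compound 4 is therefore estimated at 80000 nM, between 30000 nM and 200000 nM.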

Compound 4, half-maximal inhibitory concentration: 87100 nM
Beside the measured number, compound 4's estimate is 1.1-fold (0.04 log units) below it; the measured number falls inside the stated range.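

In this assay, the methoxy added on this ring, meta to a large group and para to a methoxy group, changes little, with an at least 1.1-fold lower number from compound 3 to compound 4 (0.05 log units; that floor lies within the scatter), and that step is only a floor because compound 3 sits at a limit. The comparison with plain phenyl looks the same, with an at least 1.1-fold lower number from compound 1 to compound 4 (0.05 log units; that floor lies within the scatter), so 2,5-dimethoxyphenyl brings no clear gain over phenyl, although compound 1 also sits at a limit. Going by these compounds alone, compound 4 also gives a second readable number, which allows the first comparison between two real numbers, and 2,5-dimethoxyphenyl cannot be told apart from the 3,4,5-trimethoxyphenyl of compound 2, with a 1.5-fold higher number from compound 2 to compound 4 (0.18 log units; within the scatter).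

Whether any group on this ring can move the number beyond the scatter stays open, because only two readable numbers exist and the other values rest on a limit: the limit of > 100000 nM in this assay, at which 2 of the 4 values shown sit. How a hydroxyl or an amine in place of this methoxy would read remains unknown from the compounds shown.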